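This account rests on a few compounds, and the source may have more. Where it says the series, first, only, none or still open, it means among the compounds named here.

Compound 1 `CCCCCCc1ccc(NC(=O)Nc2c(C(C)C)cccc2C(C)C)cc1` carries a hexyl chain on the shared core. Among the measured compounds shown here, in an assay on isolated protein for inhibition of acyl-CoA:cholesterol acyltransferase (Oryctolagus cuniculus) (on this read-out lower numbers stand for stronger inhibition and higher numbers for weaker inhibition), compound 1 gives 26 nM; of the two numbers measured it is the higher, though the gap to its only neighbour, compound 2 `CCCCCCCCCCCCc1ccc(NC(=O)Nc2c(C(C)C)cccc2C(C)C)cc1`, lies within the scatter. In this assay compound 2 gives 15 nM. For the measured compounds named here, the single measured step, a 1.7-fold lower number from compound 1 to compound 2 (0.24 log units; within the scatter), is the only one that bears on the change considered here. Compound 3 `CCCCCCCCCc1ccc(NC(=O)Nc2c(C(C)C)cccc2C(C)C)cc1` differs from compound 1 by propyl in place of hydrogen on a saturated chain carbon, six bonds along the chain from an aromatic carbon; the same difference, cut one bond further out, reads propyl to hexyl. Since the longer extension of the chain changed the number by only a 1.7-fold lower number from compound 1 to compound 2 (0.24 log units; within the scatter), the shorter extension to compound 3 is expected to give a step of similar or smaller size in this assay, downward if anything, or none beyond the scatter. The step is therefore expected to be a 1.3-fold lower number from compound 1 to compound 3 (0.11 log units; within the scatter). Compound 3 is estimated at 20 nM, within a range from 10 nM to 40 nM.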

Compound 3, half-maximal inhibitory concentration: 9 nM
For compound 3 the middle estimate is 2.2-fold (0.35 log units) above the measured one; the whole stated range lies above it.
By their numbers in this assay, from the lowest: compounds 3, 2 and 1 (each within the scatter of the next, the first and the last beyond it).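

Adding propyl at this position gives the first change in the series that clears the scatter in this assay, with a 2.9-fold lower number from compound 1 to compound 3 (0.46 log units; beyond the scatter), so lengthening the hexyl chain does register here. The further lengthening to the chain of compound 2 cannot be told apart from compound 3, since a 1.7-fold lower number from compound 2 to compound 3 (0.22 log units; within the scatter), and the values therefore show no steady trend with chain length across the three compounds. No measurement at hand accounts for this step.

The compounds shown leave open how far the number would move with a chain shorter than hexyl, such as butyl, or with a chain longer than that of compound 2. They also leave open whether a chain ending in an amine or a carboxylic acid would be tolerated at this position.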